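Series notes: removing bromo from compound 3

The compounds below may be only part of what the source reports. "The series", "measured", "known", "first", "only" and "open" are said of these compounds alone.

Three compounds of the series have numbers in an ADME assay on microsomes from liver (Homo sapiens) for metabolic stability; a higher number here means that the compound lasts longer, a lower number that the compound disappears faster. Compound 1 `CCCNC(=O)[C@H]1CC[C@H](NC(=O)c2cc3sc(Br)cc3n2Cc2ccc(OC)cc2)CC1` gives 0.0662 h. Compound 2 `CCCNC(=O)C1CCN(C(=O)c2cc3sc(C)cc3n2Cc2ccc(OC)cc2)CC1` gives 0.0448 h in this assay. Compound 3 `CCCNC(=O)C1CCN(C(=O)c2cc3cc(Br)ccc3n2Cc2ccc(OC)cc2)CC1` gives 0.0657 h in this assay. Compound 3 holds the second highest of the three numbers, but its gap to compound 1 and its gap to compound 2 both lie within the scatter, so no order among the three can be read. Among the measured compounds shown here, no two measured compounds differ in one place, so no single-point step is known. Compound 4 `CCCNC(=O)C1CCN(C(=O)c2cc3ccccc3n2Cc2ccc(OC)cc2)CC1` is not yet measured; it differs from compound 3 by hydrogen in place of bromo on an aromatic carbon. For the measured compounds named here, with no comparable step in hand, the expected step in this assay is small, a 1.1-fold lower number from compound 3 to compound 4 (0.04 log units; within the scatter), and not beyond the scatter in either direction. Compound 4 is therefore expected to give 0.06 h, in a range from 0.03 h to 0.12 h.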

Compound 4, half-life: 0.0443 h
Estimate against measurement, compound 4: 1.4-fold (0.13 log units) above, and the stated range covers the measured number.
By their numbers in this assay, from the lowest: compounds 4, 2, 3 and 1 (each within the scatter of the next).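

Hydrogen in place of bromo on this aromatic carbon gives the first single-point step in the series. In this assay it reads as a 1.5-fold lower number from compound 3 to compound 4 (0.17 log units; within the scatter) and stays within the scatter, so bromo and hydrogen at this position cannot be told apart in this read-out. No measurement at hand bears on the origin of this result.

From the compounds shown here alone, whether a methoxy group or an amine on this aromatic carbon would give a step beyond the scatter remains open. Also open, going by these compounds, is whether the same exchange reads alike on the core of compound 1.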